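Notes on a sulfanyl change across two cores

A few compounds are considered here, and "the series" means these few. Any claim that something is new, unique, unknown or untested is made for them only; others in the source may bear on it.

Compound 1 `CSC1NC(=O)n2cnc(Cc3ccc(C)cc3)c2N1` carries a methylsulfanyl group on its core and in a functional assay on CCRF-CEM cells (Homo sapiens) for cytotoxicity (on this read-out lower numbers stand for higher toxicity in this test and higher numbers for lower toxicity in this test), compound 1 gives 75300 nM. Compound 2 `Cc1ccc(CSC2NC(=O)n3cnc(Cc4ccc(C)cc4)c3N2)cc1` differs from compound 1 by 4-methylphenyl in place of hydrogen on a saturated chain carbon bound to a sulfur, and in this assay compound 2 gives 44600 nM. The step of a 1.7-fold lower number from compound 1 to compound 2 (0.23 log units; within the scatter) is therefore small and is not read as a real change.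

Compound 3 `CSC1NC(=O)n2cnc(CCCCCOCc3ccccc3)c2N1` keeps the methylsulfanyl group but sits on a different core; the difference between the two cores is not broken down here. In this assay compound 3 gives only a limit, > 120000 nM, so its true value is not known (the limit of > 120000 nM in this assay, at which 1 of the 3 values shown sits).

Compound 4 `Cc1ccc(CSC2NC(=O)n3cnc(CCCCCOCc4ccccc4)c3N2)cc1` has not yet been measured in this assay. Compound 4 differs from compound 3 by 4-methylphenyl in place of hydrogen on a saturated chain carbon bound to a sulfur. Among the compounds with values here, the change is the same one as from compound 1 to compound 2, at the same place, and it is the only change made twice.

The expectation for compound 4 rests on the measured step of a 1.7-fold lower number from compound 1 to compound 2 (0.23 log units; within the scatter), which stayed within the scatter. For the step to compound 4 a similar size is expected, an at least 1.0-fold lower number from compound 3 to compound 4 (0.03 log units; that floor lies within the scatter). Because compound 3 gave only the limit > 120000 nM, compound 4 is expected to land near that limit and may again return only a limit. Compound 4 is estimated at 110000 nM in this assay, with a range from 50000 nM to 250000 nM.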

Compound 4, half-maximal cytotoxic concentration: 343000 nM
Compound 4: middle estimate off by 3.1-fold (0.49 log units), on the low side; the measured number lies above the stated range.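

In this assay the step from compound 3 to compound 4 cannot be read, because compound 3 is held only by a limit: the limit of > 120000 nM in this assay, at which 1 of the 4 values shown sits.

The compounds shown leave open whether the change from methylsulfanyl to (4-methylbenzyl)sulfanyl has the same size on the core of compound 3 as on the core of compound 1, where it reads a 1.7-fold lower number from compound 1 to compound 2 (0.23 log units; within the scatter).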